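The compounds below may be only part of what the source reports. "The series", "measured", "known", "first", "only" and "open" are said of these compounds alone.

Measured in a toxicity assay on MCF-10A cells (Homo sapiens) for cytotoxicity, read by MTT assay, with a stated time of 48 h; on this read-out lower numbers stand for stronger inhibition and higher numbers for weaker inhibition:
- compound 1 `CC(C)n1c(/C=C2/C(=O)Nc3ccc(Br)cc32)nc2ccccc21` gives 56900 nM
- compound 2 `CCn1c(/C=C2/C(=O)Nc3ccc(F)cc32)nc2ccccc21` gives "not determined" (no result reported)
- compound 3 `Cn1c(/C=C2/C(=O)Nc3ccc(Br)cc32)nc2ccccc21` gives "not determined" (no result reported)

Compound 1 is the only one of the three with a number, and that leaves it without a rank. Its value cannot be set against any other, since compound 2 and compound 3 have no result to compare.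

The next compound to be tested is compound 4 `CC(C)n1c(/C=C2/C(=O)Nc3ccc(Cl)cc32)nc2ccccc21`, which keeps the core of compound 1 and changes it in a single place: chloro in place of bromo on an aromatic carbon. In words, this is chloro in place of bromo on an aromatic carbon of a six-membered aromatic ring of carbon only, part of a fused or bridged system of two rings.

Among the measured compounds shown here, the data hold no measured pair that shows how far such an exchange moves the read-out. With nothing to suggest a direction, no step beyond the usual scatter is expected in this assay, and the expectation rests on compound 1 at 56900 nM alone. The estimated change is a 1.1-fold higher number from compound 1 to compound 4 (0.02 log units; within the scatter), which is only an expectation. Compound 4 is expected at 60000 nM, with an estimated range from 28000 nM to 120000 nM.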

Compound 4, half-maximal inhibitory concentration: 68800 nM
For compound 4 the middle estimate is 1.1-fold (0.06 log units) below the measured one; measured number inside the range.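

In this assay the exchange of chloro in place of bromo on an aromatic carbon, at the place that is meta to a fused ring and para to a fused ring, gives a 1.2-fold higher number from compound 1 to compound 4 (0.08 log units; within the scatter) and so gives the series its first readable step. Within this one pair the two halogens are not told apart at this position, and the core of compound 1 tolerates the exchange without a change that can be separated from the scatter of the assay. No measurement is at hand that would explain this result or link it to any property of either halogen.

Steps involving compound 2 and compound 3 cannot be read, so the pair of compound 1 and compound 4 remains the only comparison available. Going by these compounds, whether a group of another kind at this position, such as an amine, a carboxylic acid or a methoxy group, would move the number beyond the scatter stays open, since two halogens alone say nothing about such groups.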